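This account rests on a few compounds, and the source may have more. Where it says the series, first, only, none or still open, it means among the compounds named here.

Compound 2 `C#CCSc1cnc2ccccc2c1[Se]CC#CCO` shares its core with compound 1 `OCC#CCSc1cnc2ccccc2c1[Se]CC#CCO` and compound 3 `C#CCSc1cnc2ccccc2c1SCC#CCO`. In a functional assay on CCRF-CEM cells (Homo sapiens) for cytotoxicity, read by sulforhodamine B assay, with a stated time of 72 h (on this read-out lower numbers stand for stronger inhibition and higher numbers for weaker inhibition), compound 1 gives 1.4 ug/mL, compound 2 gives 3.2 ug/mL and compound 3 gives 3.2 ug/mL. Compound 2 stands level with compound 3, no change at the digits printed from compound 2 to compound 3 (within the scatter), and together they carry the highest numbers of the three; compound 1 is the furthest away, a 2.3-fold higher number from compound 1 to compound 2 (0.36 log units; beyond the scatter). Compound 4 `CSc1cnc2ccccc2c1[Se]CC#CCO` differs from compound 2 by hydrogen in place of ethynyl on a saturated chain carbon bound to a sulfur. For the measured compounds named here, the one measured step that bears on this, a 2.3-fold higher number from compound 1 to compound 2 (0.36 log units; beyond the scatter), also shortened the chain bound to the same sulfur and gave a modest rise. A further shortening is therefore expected to raise the number by a modest step once more, a 1.7-fold higher number from compound 2 to compound 4 (0.24 log units; within the scatter). Compound 4 is estimated at 5.5 ug/mL, within 2.5 ug/mL to 12 ug/mL.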

Compound 4, concentration for 50% inhibition: 0.5 ug/mL
Compound 4: the middle estimate sits 11-fold (1.04 log units) above what was measured, outside the stated range (below it).
By their numbers in this assay, from the lowest: compound 4; then compound 1; then compounds 2 and 3 (each within the scatter of the next).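

In this assay the change from propargyl to methyl on the sulfur gives a 6.4-fold lower number from compound 2 to compound 4 (0.81 log units; beyond the scatter) and the larger change to the same methyl gives a 2.8-fold lower number from compound 1 to compound 4 (0.45 log units; beyond the scatter), so the number here does not simply rise as this chain gets shorter. Compound 1 and compound 2 alone could not show this turn, which appears only once the triple bond leaves the chain. Nothing shown explains the turn. From the compounds shown here alone, whether ethyl, a longer saturated chain or an amine-bearing chain on this sulfur would follow methyl stays open. Also open, going by these compounds, is how sulfur in place of selenium behaves with methyl present.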